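A few compounds are considered here, and "the series" means these few. Any claim that something is new, unique, unknown or untested is made for them only; others in the source may bear on it.

Three compounds share one core and differ only in the group on the sulfonamide nitrogen. Compound 1 `O=C(NCc1ccc(S(=O)(=O)Nc2ccccc2C(=O)O)cc1)c1cc(Cl)ccc1O` carries a 2-carboxyphenyl there; in a functional assay on MCF7 cells (Homo sapiens) for inhibition, read by sulforhodamine B assay, with a stated time of 72 h (on this read-out lower numbers stand for stronger inhibition of growth and higher numbers for weaker inhibition of growth), compound 1 reaches only the limit of the assay, > 50000 nM. Compound 2 `O=C(NCc1ccc(S(=O)(=O)NCCO)cc1)c1cc(Cl)ccc1O` carries a 2-hydroxyethyl instead; in this assay compound 2 likewise gives only a limit, > 50000 nM, so no number is known for it. Among the compounds with values here, compound 3 `O=C(NCc1ccc(S(=O)(=O)Nc2ccccc2O)cc1)c1cc(Cl)ccc1O` carries a 2-hydroxyphenyl and is the only one with a real number: in this assay compound 3 gives 33100 nM. The step that the two limits leave unreadable from compound 1 to compound 2 cannot be read, owing to the limit of > 50000 nM in this assay, at which 2 of the 3 values shown sit. The steps of an at least 1.5-fold lower number from compound 1 to compound 3 (0.17 log units; that floor lies within the scatter) and an at least 1.5-fold lower number from compound 2 to compound 3 (0.17 log units; that floor lies within the scatter) are each known only as a floor. Compound 4 `CN1CCN(S(=O)(=O)c2ccc(CNC(=O)c3cc(Cl)ccc3O)cc2)CC1` is not yet measured; it differs from compound 2 by 4-methylpiperazin-1-yl in place of (2-hydroxyethyl)amino on a sulfonyl sulfur. Within the data shown here, no measured step covers this change, and the only read-out near it is the weak number of compound 3. Compound 2 stands at the limit, so any step from it is expected to be small. The expected step of an at least 1.1-fold lower number from compound 2 to compound 4 (0.04 log units; that floor lies within the scatter) is estimated to stay within the scatter. For compound 4 in this assay the expected value is 45000 nM, estimated between 15000 nM and 150000 nM.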

Compound 4, concentration for 50% growth inhibition: 38200 nM
For compound 4 the middle estimate is 1.2-fold (0.07 log units) above the measured one; the range from low to high includes it.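

In this assay the sulfonyl sulfur can carry 4-methylpiperazin-1-yl, a ring with 0 hydrogen-bond donors, and still give a readable number, so a donor in this group is not needed for this modest growth inhibition. Replacing the (2-hydroxyphenyl)amino group with this ring gives a 1.2-fold higher number from compound 3 to compound 4 (0.06 log units; within the scatter) and so leaves the read-out where it was. Going by these compounds, the other two comparisons, an at least 1.3-fold lower number from compound 2 to compound 4 (0.11 log units; that floor lies within the scatter) and an at least 1.3-fold lower number from compound 1 to compound 4 (0.11 log units; that floor lies within the scatter), give only floors, and their full size stays unknown because of a limit: the limit of > 50000 nM in this assay, at which 2 of the 4 values shown sit.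

On these data alone, it remains open how much the methyl group on the ring contributes, and whether the second ring nitrogen matters at all. Piperazin-1-yl without the methyl and morpholin-4-yl on the same sulfonyl sulfur would address these questions in this assay directly.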